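Swapping Fluoro for Trifluoromethyl on the Benzylamine Ring

The compounds below may be only part of what the source reports. "The series", "measured", "known", "first", "only" and "open" are said of these compounds alone.

Compound 1 `COc1ccc2nc(C)cc(NCc3ccc(F)c(F)c3)c2c1` was tested in a functional assay on MCF-10A cells (Homo sapiens) for antiproliferative activity, with a stated time of 48 h (on this read-out lower numbers stand for an effect already at smaller amounts and higher numbers for an effect only at larger amounts of compound), where compound 1 gives 9100 nM. Compound 3 `COc1ccc2nc(C)cc(NCc3ccc(F)c(C(F)(F)F)c3)c2c1` carries trifluoromethyl in place of fluoro on an aromatic carbon; in this assay compound 3 gives 11300 nM, and the step is a 1.2-fold higher number from compound 1 to compound 3 (0.09 log units; within the scatter). Compound 2 `COc1ccc2nc(C)cc(NCc3c(F)cccc3F)c2c1` has the same atoms as compound 1, joined differently; how the two cores differ is not broken down here. In this assay compound 2 gives 13600 nM, a number within the scatter of those of compound 1 and compound 3. Compound 4 `COc1ccc2nc(C)cc(NCc3c(F)cccc3C(F)(F)F)c2c1` has not yet been measured. It differs from compound 2 by trifluoromethyl in place of fluoro on an aromatic carbon. This is the same kind of change as that from compound 1 to compound 3, not the same: in compound 3 the trifluoromethyl sits ortho to a fluoro group and meta to a large group, whereas in compound 4 it sits ortho to a large group and meta to a fluoro group. The expected step is a 1.2-fold higher number from compound 2 to compound 4 (0.07 log units; within the scatter), because the earlier step of a 1.2-fold higher number from compound 1 to compound 3 (0.09 log units; within the scatter) stayed within the scatter. Compound 4 is therefore estimated at 16000 nM in this assay, with a range from 7500 nM to 35000 nM.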

Compound 4, half-maximal effective concentration: 14200 nM
Beside the measured number, compound 4's estimate is 1.1-fold (0.05 log units) above it; measured number inside the range.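

In this assay, trifluoromethyl in place of fluoro on an aromatic carbon gives a 1.0-fold higher number from compound 2 to compound 4 (0.02 log units; within the scatter), so the change again leaves the number within the scatter. Set beside the earlier step, the change carries over from one core to the other without a difference that can be told apart: the same change on two cores in this assay, a 1.2-fold higher number (0.09 log units; within the scatter) from compound 1 to compound 3 and a 1.0-fold higher number (0.02 log units; within the scatter) from compound 2 to compound 4, 1.2-fold (0.08 log units) apart, within the scatter of two such steps. This shows that the swap was equally silent on these two cores, including in compound 4, where the trifluoromethyl sits ortho to a large group and meta to a fluoro group, but two pairs do not show that it would stay silent on any further core, nor do they explain why it had so little effect here.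

The compounds shown carry only fluoro and trifluoromethyl on the benzylamine ring, so it remains open whether an amine, a carboxylic acid or a longer chain there would move the number beyond the scatter. As far as these compounds go, whether the swap behaves in the same way in other cell lines also remains open.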